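The source may hold more compounds than are shown below. What is called first, only, known or untested is meant among the compounds shown, and "the series" means these compounds.

Working notes on the series, starting from compound 1 (`CC(=O)N1N=C(Nc2nc3ccc(Cl)cc3s2)CC1c1ccccc1`). In a functional assay on the whole organism (strain albino) with Mus musculus as the target, with a stated time of 0.5 h (on this read-out lower numbers stand for an effect already at smaller amounts and higher numbers for an effect only at larger amounts of compound), compound 1 is entered as "not determined" (no result reported) and so has no place on the numerical scale. Compound 3 (`CC(=O)N1N=C(Nc2nc3ccc([N+](=O)[O-])cc3s2)CC1c1ccccc1`) is in the same position, entered as "not determined" (no result reported) in this assay with no number to compare. Among the compounds with values here, only compound 2 (`CC(=O)N1N=C(Nc2nc3ccc(C)cc3s2)CC1c1ccccc1`) carries a number, 112 umol/kg in this assay, so the series offers a single reference point and no measured step.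

Still to be measured is compound 4 (`COc1ccc(C2CC(Nc3nc4ccc(Cl)cc4s3)=NN2C(C)=O)cc1`). Its change from compound 1 is methoxy in place of hydrogen on an aromatic carbon and amounts to methoxy in place of hydrogen on an aromatic carbon, para to a large group, or phenyl to 4-methoxyphenyl when cut one bond further out. With no number for compound 1, the size of this step cannot be read from the data. No step beyond the usual scatter is expected in this assay, in either direction, so the working reference stays compound 2 at 112 umol/kg as the only available anchor. A further entry without a number also remains possible. For compound 4 the expected dose is 110 umol/kg with an estimated range of 45 umol/kg to 270 umol/kg in this assay if a number is reported.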

Compound 4, dose for half-maximal effect: 97.3 umol/kg
For compound 4 the middle estimate is 1.1-fold (0.05 log units) above the measured one; low and high end bracket the measured number.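

Compound 4 carries a number while compound 1 is entered as "not determined" (no result reported), so no step can be read between compound 1 and compound 4. The compounds shown leave open what the change from phenyl to 4-methoxyphenyl does to the dose on the shared core. No supporting evidence bears on this result.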